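The source may hold more compounds than are shown below. What is called first, only, known or untested is meant among the compounds shown, and "the series" means these compounds.

Working notes on the series. The shared core carries a sulfonyl sulfur whose other neighbour is a sulfonamide nitrogen in a ring, and the three measured compounds differ only in the aromatic group on that sulfonyl sulfur: compound 1 `CC1CCN(C2CCN(S(=O)(=O)c3cccc(-c4ccccc4C(F)(F)F)c3)CC2)CC1`, compound 2 `CC1CCN(C2CCN(S(=O)(=O)c3cccc(Br)c3)CC2)CC1` and compound 3 `CC1CCN(C2CCN(S(=O)(=O)c3cccc(-c4ccc5ccccc5c4)c3)CC2)CC1`. In an ADME assay on HCT-116 cells (Homo sapiens) for cytotoxicity, read by CellTiter-Glo, with a stated time of 72 h (on this read-out lower numbers stand for stronger inhibition and higher numbers for weaker inhibition), compound 1 gives > 5000 nM, which is a limit of the assay and not a number. In this assay compound 2 likewise gives > 5000 nM, again a limit. In this assay compound 3 gives > 5000 nM, also a limit. Compound 2 thus stands at the limit of > 5000 nM in this assay, at which 3 of the 3 values shown sit, and the other two values stand there with it. Among the compounds with values here, the steps a step that the two limits leave unreadable from compound 1 to compound 2, a step that the two limits leave unreadable from compound 1 to compound 3 and a step that the two limits leave unreadable from compound 2 to compound 3 are all unreadable in size, so no step in this set has a readable magnitude.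

Compound 4 `CC1CCN(C2CCN(S(=O)(=O)c3cccnc3)CC2)CC1` differs from compound 2 by pyridin-3-yl in place of 3-bromophenyl on a sulfonyl sulfur. Within the data shown here, no measured step bears on this change with a readable size; every exchange on an aromatic carbon so far left the read-out at the limit. Compound 4 is therefore expected to remain at the limit, with a step that the limit leaves unreadable from compound 2 to compound 4 expected to be nothing beyond the scatter. The estimate for compound 4 in this assay is 12000 nM, with an expected range from 4000 nM to 40000 nM.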

Compound 4, half-maximal inhibitory concentration: > 10000 nM
Compound 4 was reported as a limit (the forecaster's own chance of this, stated with the estimate: 85%); the middle value lies beyond the limit too.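

In this assay compound 4 gives > 10000 nM, a limit and not a number, so its step from compound 2, itself held at a limit, cannot be read. The compounds shown leave open whether any aromatic group on the sulfonyl sulfur brings a readable value.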